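A few compounds are considered here, and "the series" means these few. Any claim that something is new, unique, unknown or untested is made for them only; others in the source may bear on it.

Measured compounds:
Compound 1, `O=C(O)CCCCCCCCCCn1nc(-c2ccccc2)c(-c2ccccc2)c1-c1ccccc1`, in a functional assay for inhibition, with Homo sapiens as the target (on this read-out higher numbers stand for weaker inhibition and lower numbers for stronger inhibition), compound 1 gives 18600 nM.
Compound 2, `O=C(O)CCCCCCCCn1nc(-c2ccccc2)c(Cc2ccccc2)c1-c1ccccc1`, in this assay compound 2 gives only a limit, > 68000 nM.
Compound 3, `O=C(O)CCCCCCCCCn1cc(-c2ccccc2)c(-c2ccccc2)n1`, in this assay compound 3 gives only a limit, > 81000 nM.

Among the compounds with values here, compound 1 stands as the only compound with an actual number in this assay; the two other measured compounds reach only a limit of the assay and no number. The limit of compound 2 is the one described in the limit of > 68000 nM in this assay, at which 1 of the 3 values shown sits. The limit of compound 3 is the one described in the limit of > 81000 nM in this assay, at which 1 of the 3 values shown sits. Within the data shown here, none of these three compounds differs from another in a single place, so no measured step between them is available.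

The unmeasured compound is compound 4, `c1ccc(-c2nn(CCCCCCCCc3nnn[nH]3)c(-c3ccccc3)c2-c2ccccc2)cc1`. It differs from compound 1 in one place: 1H-tetrazol-5-yl in place of 2-carboxyethyl on a saturated chain carbon, eight bonds along the chain from an aromatic nitrogen. The chain that carries the group stays the same length in atoms, and the shared core of compound 1 is untouched; only the acid end of the chain is exchanged for the 1H-tetrazol-5-yl ring.

Among the measured compounds shown here, nothing among the measured compounds shows how such an exchange moves this read-out. Compound 1 is expected to remain the nearest guide, and the step is estimated to be small, at most a modest move toward stronger inhibition, roughly at the edge of the usual scatter, a 1.6-fold lower number from compound 1 to compound 4 (0.19 log units; within the scatter). Compound 4 is therefore expected to give about 12000 nM in this assay, within a range from 4000 nM to 40000 nM.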

Compound 4, half-maximal inhibitory concentration: 1040 nM
Compound 4: middle estimate off by 12-fold (1.06 log units), on the high side; measured number outside the range, below it.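

In this assay, the 1H-tetrazol-5-yl ring in place of 2-carboxyethyl, on a saturated chain carbon eight bonds along the chain from an aromatic nitrogen, gives an 18-fold lower number from compound 1 to compound 4 (1.25 log units; beyond the scatter) with the shared core untouched, and a lower number here means stronger inhibition. Within the data shown here, this is the first single-place comparison, and it shows that the far end of this chain is not a silent spot: what sits there can by itself move the read-out well beyond the usual scatter. The two groups have the same counts of heavy atoms and hydrogen-bond donors but differ in their ring and in their hydrogen-bond acceptors, and nothing measured here says which of these differences, if any, lies behind the step.

This is one step on one core, so it remains open whether the 1H-tetrazol-5-yl ring would give a similar step on a shorter or a longer chain, or on the other cores shown. Going by these compounds, it is also open how other end groups, such as a primary amide, a sulfonamide or a hydroxamic acid, would compare with these two at the same place.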